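From compound 3 to compound 4: one substituent exchanged

The compounds below may be only part of what the source reports. "The series", "measured", "known", "first", "only" and "open" are said of these compounds alone.

In a functional assay on HepG2 cells (Homo sapiens) for cytotoxicity, read by MTT assay (a higher number here means a weaker inhibitor, a lower number a stronger inhibitor), compound 1 (`COc1ccc(/C=C/C(=O)c2ccc(OC)c3c2OC(C)(C)C=C3)cc1O`) gives 450 nM, compound 2 (`C=CC(=O)Oc1cc(/C=C/C(=O)c2ccc(OC)c3c2OC(C)(C)C=C3)ccc1OC`) gives 160 nM and compound 3 (`COc1cccc(C(=O)Oc2cc(/C=C/C(=O)c3ccc(OC)c4c3OC(C)(C)C=C4)ccc2OC)c1`) gives 870 nM. Two gaps place that last number: a 1.9-fold higher number from compound 1 to compound 3 (0.29 log units; within the scatter), and a 5.4-fold higher number from compound 2 to compound 3 (0.74 log units; beyond the scatter). Compound 4 (`COc1ccc(/C=C/C(=O)c2ccc(OC)c3c2OC(C)(C)C=C3)cc1CS(C)(=O)=O`) is related to compound 3 by a single exchange, ((methylsulfonyl)methyl in place of ((3-methoxyphenyl)carbonyl)oxy on an aromatic carbon), with (methylsulfonyl)methyl in place of ((3-methoxyphenyl)carbonyl)oxy on an aromatic carbon, ortho to a methoxy group.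

Going by the values given here, no measured step makes this exchange, and no measured compound carries the entering group. The nearest evidence comes from changing the group on the oxygen. Compound 2 shows a 2.8-fold lower number from compound 1 to compound 2 (0.45 log units; beyond the scatter), and compound 3 shows a 1.9-fold higher number from compound 1 to compound 3 (0.29 log units; within the scatter). These steps are modest or smaller and point in both directions, so a modest step at most is expected, most likely none beyond the scatter, with a slight lean towards the number of compound 1. The expected value for compound 4 is 600 nM, with an estimated range of 200 nM to 1800 nM. This estimate means an expected 1.5-fold lower number from compound 3 to compound 4 (0.16 log units; within the scatter).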

Compound 4, half-maximal inhibitory concentration: 9180 nM
Compound 4: the middle estimate sits 15-fold (1.18 log units) below what was measured; the measured number lies above the stated range.
By their numbers in this assay, from the lowest: compound 2; then compounds 1 and 3 (each within the scatter of the next); then compound 4.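

In this assay, (methylsulfonyl)methyl on this aromatic carbon, ortho to a methoxy group, gives an 11-fold higher number from compound 3 to compound 4 (1.02 log units; beyond the scatter) and also a 57-fold higher number from compound 2 to compound 4 (1.76 log units; beyond the scatter) and a 20-fold higher number from compound 1 to compound 4 (1.31 log units; beyond the scatter) in the comparison with the free hydroxy. The earlier changes, all made on the oxygen, gave modest steps at most, so this position proves far more sensitive once that oxygen gives way to a group attached through carbon, and compound 4 has the highest number of the four by a large step. Nothing measured here accounts for the size of this rise.

As far as these compounds go, it remains open whether the rise follows from losing the oxygen attachment or from the methylsulfonyl group itself. An amine or a carboxylic acid on this carbon, or a longer chain carrying the methylsulfonyl group, would help to separate these two readings.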